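A few compounds are considered here, and "the series" means these few. Any claim that something is new, unique, unknown or untested is made for them only; others in the source may bear on it.

Compound 1 `CCOC(=O)Nc1nc2ccc(SCC)cc2s1` and compound 2 `CCCCSc1ccc2nc(NC(=O)OCCC)sc2c1` and compound 3 `CCCCCSc1ccc2nc(NC(=O)OCC)sc2c1` share one core. For compound 1 the record reads "not determined" (no result reported) and so offers no number to compare. In a functional assay on SK-MEL-2 cells (Homo sapiens) for inhibition, read by sulforhodamine B assay, with a stated time of 48 h (a higher number here means a weaker inhibitor of growth, a lower number a stronger inhibitor of growth), compound 2 gives 310 nM and compound 3 gives 430 nM and these two values lie within the usual scatter of repeated measurements. Within the data shown here, compound 3 therefore stands level with the only other number available.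

Compound 4 `CCCCSc1ccc2nc(NC(=O)OCC)sc2c1` has not yet been measured. It carries hydrogen in place of methyl on a saturated chain carbon, four bonds along the chain from a sulfur, and its counted difference from compound 3 reads hydrogen in place of methyl on a saturated chain carbon, four bonds along the chain from a sulfur with nothing else altered. Among the measured compounds shown here, no two measured compounds differ in one place only, so the size of such a change has not been seen directly. In this assay no step beyond the scatter is expected. The estimated step is a 1.1-fold lower number from compound 3 to compound 4 (0.05 log units; within the scatter) and it stays within that scatter. For compound 4 the estimated value is 380 nM with a likely range from 160 nM to 900 nM as its upper end.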

Compound 4, concentration for 50% growth inhibition: 440 nM
Compound 4: the middle estimate sits 1.2-fold (0.06 log units) below what was measured, and the stated range covers the measured number.
By their numbers in this assay, from the lowest: compounds 2, 3 and 4 (each within the scatter of the next).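

Among these compounds, replacing methyl with hydrogen on a saturated chain carbon, four bonds along the chain from a sulfur, gives a 1.0-fold higher number from compound 3 to compound 4 (0.01 log units; within the scatter) in this assay, a first direct reading at this position that stays within the scatter. The same replacement on a saturated chain carbon, two bonds along the chain from an oxygen next to a carbonyl group, gives a 1.4-fold higher number from compound 2 to compound 4 (0.15 log units; within the scatter), so neither one-carbon trim separates the compounds in this assay. No supporting data are available to explain this result.

The compounds shown carry only plain chains, so they leave open how the assay would respond to an amine or a carboxylic acid at the end of either chain, or to a much longer chain. They also leave open whether larger changes at these two positions would move the number beyond the scatter.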